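Diethylamino in place of amino: expected step

The source may hold more compounds than are shown below. What is called first, only, known or untested is meant among the compounds shown, and "the series" means these compounds.

In a functional assay on the whole organism with Rattus norvegicus as the target (a lower number here means that less compound is needed, a higher number that more compound is needed for the effect), compound 3 `CCOC(=O)C(=O)Nc1cccc(N)c1C#N` has the lowest number of the three measured, at 0.05 mg/kg. Compound 2 `CCOC(=O)C(=O)Nc1ccc(N(C)C)cc1C#N` gives 1 mg/kg and compound 1 `CCOC(=O)C(=O)Nc1cccc(OC)c1C#N` gives 5.3 mg/kg. Compound 4 `CCOC(=O)C(=O)Nc1cccc(N(CC)CC)c1C#N` carries diethylamino in place of amino on an aromatic carbon, ortho to a cyano group (diethylamino in place of amino on an aromatic carbon). Within the data shown here, one measured step bears on this place: a 110-fold lower number from compound 1 to compound 3 (2.03 log units; beyond the scatter), a large step with amino in place of methoxy. Among the measured compounds shown here, no single-place step links compound 2 to compound 3, so compound 2 gives only indirect guidance. Losing the amino is therefore expected to bring a large step towards a higher number in this assay. The estimated step is a 30-fold higher number from compound 3 to compound 4 (1.48 log units; beyond the scatter). For compound 4 the expected value is 1.5 mg/kg, with an estimated range of 0.25 mg/kg to 8 mg/kg.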

Compound 4, dose for half-maximal effect: 0.7 mg/kg
For compound 4 the middle estimate is 2.1-fold (0.33 log units) above the measured one; measured number inside the range.
By their numbers in this assay, from the lowest: compound 3; then compounds 4 and 2 (each within the scatter of the next); then compound 1.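

In this assay, diethylamino in place of amino gives a 14-fold higher number from compound 3 to compound 4 (1.15 log units; beyond the scatter), so this position, ortho to a cyano group, does not tolerate the larger group without a large loss. Diethylamino still keeps an advantage over methoxy, with a 7.6-fold lower number from compound 1 to compound 4 (0.88 log units; beyond the scatter), which orders the three groups here as amino, diethylamino, methoxy, from lowest number to highest. Nothing available explains these steps. Open, on these data alone, is whether methylamino or ethylamino at this place would sit nearer compound 3 or compound 4. Also open, as far as these compounds go, is how a longer chain on the nitrogen would read.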